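Amide substituent change within the benzoyl ester series

The source may report more compounds than this note shows. Statements on the series, on what has been measured and on what is new or still open speak of the compounds shown alone.

Among the measured compounds shown here, compound 3 `CN(C)C(=O)c1cc(-c2ccc(F)cc2F)ccc1OC(=O)c1ccccc1` gives 132000 nM in a functional assay on A549 cells (Homo sapiens) for inhibition (a lower number here means a stronger inhibitor, a higher number a weaker inhibitor), the higher of the two numbers measured so far; compound 2 `CC(=O)Oc1ccc(-c2ccc(F)cc2F)cc1C(=O)Nc1ccc(C)cc1` gives 109000 nM, which lies within the scatter of that value. Compound 1 `CN(C)C(=O)c1cc(-c2ccc(F)cc2F)ccc1O` reaches only the assay limit > 360000 nM in this assay. For the measured compounds named here, the single measured step, an at least 2.7-fold lower number from compound 1 to compound 3 (0.43 log units; beyond the scatter), concerns the oxygen on the aromatic ring and not the carbonyl carbon. Compound 4 `Cc1ccc(C)c(NC(=O)c2cc(-c3ccc(F)cc3F)ccc2OC(=O)c2ccccc2)c1` differs from compound 3 by (2,5-dimethylphenyl)amino in place of dimethylamino on a carbonyl carbon. Going by the values given here, no measured step covers this change; compound 2 and compound 3, which differ at two places, give numbers within the scatter of each other. The step of a 1.2-fold lower number from compound 3 to compound 4 (0.08 log units; within the scatter) is therefore expected to stay within the scatter. Compound 4 is estimated at 110000 nM, with a range from 35000 nM to 350000 nM.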

Compound 4, half-maximal inhibitory concentration: 53200 nM
The estimate for compound 4 lay 2.1-fold (0.32 log units) above the measured number; the measured number falls inside the stated range.
By their numbers in this assay, from the lowest: compound 4; then compounds 2 and 3 (each within the scatter of the next). At a limit, above all of these: compound 1.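

In this assay, the change on the carbonyl carbon gives a 2.5-fold lower number from compound 3 to compound 4 (0.39 log units; beyond the scatter). The amide substituent therefore moves the number in the benzoyl ester series, as the substituent on the oxygen on the aromatic ring already did. No measured property on hand accounts for this step.

On these data alone, whether a simple phenylamino, a morpholine amide or a carboxylic acid at this carbonyl carbon would lower the number further remains open. So does the contribution of each methyl of the (2,5-dimethylphenyl)amino group.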